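From 3,5-dimethylphenyl to 2-methoxyphenyl: compound 3 to compound 4

The source may hold more compounds than are shown below. What is called first, only, known or untested is meant among the compounds shown, and "the series" means these compounds.

Measured so far in a functional assay on DU-145 cells (Homo sapiens) for inhibition, read by trypan blue exclusion, with a stated time of 96 h; on this read-out higher numbers stand for weaker inhibition of growth and lower numbers for stronger inhibition of growth:
- compound 1 `COc1ccccc1/C=C(/SCc1ccc(Cl)c(Cl)c1)C(=O)c1ccc(Cl)cc1`: 10000 nM
- compound 2 `COc1ccccc1/C=C(/SCc1ccc(F)cc1)C(=O)c1ccc(Cl)cc1`: 10000 nM
- compound 3 `Cc1cc(C)cc(/C=C(/Sc2ccc(Br)cc2)C(=O)c2ccc(Cl)cc2)c1`: 10000 nM

All three compounds give the same number, so compound 3 at 10000 nM stands level with the other two in this assay. The next molecule, compound 4 `COc1ccccc1/C=C(/Sc1ccc(Br)cc1)C(=O)c1ccc(Cl)cc1`, differs from compound 3 in one place: 2-methoxyphenyl in place of 3,5-dimethylphenyl on a double-bonded chain carbon bound to a double-bonded chain carbon. In words, this is 2-methoxyphenyl in place of 3,5-dimethylphenyl on a double-bonded chain carbon bound to a double-bonded chain carbon.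

Among the compounds with values here, no measured pair tests this exact swap. Within the data shown here, the one measured step, no change at the digits printed from compound 1 to compound 2 (within the scatter), changes a different group, so it bears on this swap only indirectly. It does show that one change elsewhere in the molecule left the number where it was. Compound 1 and compound 2 also carry 2-methoxyphenyl, and that group appears there with 10000 nM for compound 2, the same number as for compound 3. Among the measured compounds shown here, nothing measured so far points to a move in either direction, so no step beyond the scatter is expected. The expected change is a 1.3-fold lower number from compound 3 to compound 4 (0.10 log units; within the scatter). With so few compounds the estimate stays wide, and a surprise remains possible.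

Compound 4 is estimated at 8000 nM, with an expected range from 2000 nM to 15000 nM.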

Compound 4, concentration for 50% growth inhibition: 10000 nM
Compound 4: middle estimate off by 1.3-fold (0.10 log units), on the low side, and the stated range covers the measured number.
By their numbers in this assay, from the lowest: compounds 1, 2, 3 and 4 (each within the scatter of the next).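

In this assay the swap of 3,5-dimethylphenyl for 2-methoxyphenyl on a double-bonded chain carbon bound to a double-bonded chain carbon gives the first direct test of this position (no change at the digits printed from compound 3 to compound 4 (within the scatter)). The entering group brings one hydrogen-bond acceptor and the leaving group none, yet the number does not respond to that difference. The group on the sulfur is also tested more widely than before, since 4-bromophenyl can be read against 4-fluorobenzyl (no change at the digits printed from compound 2 to compound 4 (within the scatter)) and against 3,4-dichlorobenzyl (no change at the digits printed from compound 1 to compound 4 (within the scatter)), so a phenyl group on the sulfur reads the same as these benzyl groups, whereas the earlier step only compared two benzyl groups.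

With all of these compounds sharing one number, it remains open whether an amine or a carboxylic acid at either of these two places would shift growth inhibition at all. No independent measurement is available to explain why these swaps leave the number in place.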